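From an Aryl to a Substituted Benzyl on the Ring Amine

A few compounds are considered here, and "the series" means these few. Any claim that something is new, unique, unknown or untested is made for them only; others in the source may bear on it.

Of the compounds shown here, three sharing one core have been tested in an assay on CHO cells for displacement of a labelled ligand from adenosine receptor A1 (Homo sapiens), read by scintillation counting, with a stated time of 90 min, in the presence of a further agent that is not named here; on this read-out lower numbers stand for stronger inhibition and higher numbers for weaker inhibition.
Compound 1 `CCCn1c(=O)[nH]c2nc(-c3ccc(S(=O)(=O)N4CCN(C)CC4)cc3)[nH]c2c1=O` gives 334 nM.
Compound 2 `CCCn1c(=O)[nH]c2nc(-c3ccc(S(=O)(=O)N4CCN(Cc5cccc(Br)c5)CC4)cc3)[nH]c2c1=O` gives 928 nM.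
Compound 3 `CCCn1c(=O)[nH]c2nc(-c3ccc(S(=O)(=O)N4CCN(c5ccc(C)cc5)CC4)cc3)[nH]c2c1=O` gives > 1000 nM.

For compound 3 that reading is only a limit of the assay, not a number (the limit of > 1000 nM in this assay, at which 1 of the 3 values shown sits). Compound 4 `CCCn1c(=O)[nH]c2nc(-c3ccc(S(=O)(=O)N4CCN(Cc5ccc(Br)c(F)c5)CC4)cc3)[nH]c2c1=O` differs from compound 3 by 4-bromo-3-fluorobenzyl in place of 4-methylphenyl on an amine nitrogen in a ring. Among the compounds with values here, no measured step swaps an aryl group for a benzyl group on this ring nitrogen. The nearest guides are a 2.8-fold higher number from compound 1 to compound 2 (0.44 log units; beyond the scatter) and an at least 2.9-fold higher number from compound 1 to compound 3 (0.47 log units; beyond the scatter), which place a benzyl group and an aryl group a similar distance from compound 1, and an at least 1.0-fold higher number from compound 2 to compound 3 (0.03 log units; that floor lies within the scatter), which shows no resolved gap between the two. Because compound 2 gives 928 nM with the same kind of group, compound 4 is expected to sit near it, and the step of a number no higher from compound 3 to compound 4 (the limit leaves the size open) is expected to be small. The estimate for compound 4 in this assay is 1000 nM, between 400 nM and 2500 nM.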

Compound 4, inhibition constant: 326 nM
Beside the measured number, compound 4's estimate is 3.1-fold (0.49 log units) above it; measured number outside the range, below it.
By their numbers in this assay, from the lowest: compounds 4 and 1 (each within the scatter of the next); then compound 2. At a limit, above all of these: compound 3.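

In this assay, the substitution on the benzyl ring matters at this ring nitrogen, with a 2.8-fold lower number from compound 2 to compound 4 (0.45 log units; beyond the scatter). Replacing methyl with the bulkier-counting 4-bromo-3-fluorobenzyl group leaves the reading unresolved from the original, with a 1.0-fold lower number from compound 1 to compound 4 (0.01 log units; within the scatter). The 4-methylphenyl group gives only a limit, and the swap to this benzyl group gives an at least 3.0-fold lower number from compound 3 to compound 4 (0.48 log units; beyond the scatter).

Which of the bromine and the fluorine accounts for the difference stays open. So does how an unsubstituted benzyl, a 4-bromobenzyl or a 3-fluorobenzyl group would read here.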